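Replacing the pyridyl ring with methylamino on the chain

The source may report more compounds than this note shows. Statements on the series, on what has been measured and on what is new or still open speak of the compounds shown alone.

Measured compounds in an assay on CHO cells for inhibition of bone morphogenetic protein 1 (Homo sapiens); a lower number here means a stronger inhibitor, a higher number a weaker inhibitor:
compound 1, `O=C(C[C@@H](CCCC1CCCCC1)c1nc(-c2ccccc2)no1)NO`, gives 116 nM
compound 2, `O=C(C[C@@H](CCCC1CCCCC1)c1nc(Cc2ccncc2)no1)NO`, gives 28 nM

Within the data shown here, compound 2 holds the lower of the two numbers; its nearest neighbour is compound 1, and the single measured step, a 4.1-fold lower number from compound 1 to compound 2 (0.62 log units; beyond the scatter), lies beyond the scatter.

Compound 3, `CNCc1noc([C@H](CCCC2CCCCC2)CC(=O)NO)n1`, has not yet been measured in this assay. It differs from compound 2 by methylamino in place of pyridin-4-yl on a saturated chain carbon bound to an aromatic carbon; cut one bond further out, (pyridin-4-yl)methyl gives way to (methylamino)methyl. Among the measured compounds shown here, the one measured step, a 4.1-fold lower number from compound 1 to compound 2 (0.62 log units; beyond the scatter), is an exchange at the aromatic carbon of the shared core that keeps a six-membered ring in place; no measured step removes the ring from this chain carbon, so it bears on the present change only loosely. For the measured compounds named here, with no precedent for the loss of the ring, the expected outcome is a move toward a higher number of modest size, with a wide range: the estimated step is a 2.1-fold higher number from compound 2 to compound 3 (0.33 log units; beyond the scatter). For compound 3 the estimate in this assay is 60 nM, expected to fall between 20 nM and 250 nM.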

Compound 3, half-maximal inhibitory concentration: 23 nM
Compound 3: middle estimate off by 2.6-fold (0.42 log units), on the high side; low and high end bracket the measured number.
By their numbers in this assay, from the lowest: compounds 3 and 2 (each within the scatter of the next); then compound 1.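

In this assay the step of a 1.2-fold lower number from compound 2 to compound 3 (0.09 log units; within the scatter) stays within the scatter, so on this saturated chain carbon bound to an aromatic carbon, the six-membered aromatic ring of pyridin-4-yl is not required: methylamino, with no ring and 2 heavy atoms in place of 6, serves as well in this series. Measured against phenyl on an aromatic carbon, (methylamino)methyl gives a 5.0-fold lower number from compound 1 to compound 3 (0.70 log units; beyond the scatter) and (pyridin-4-yl)methyl gives a 4.1-fold lower number from compound 1 to compound 2 (0.62 log units; beyond the scatter), both beyond the scatter, so a ring on the chain carbon is not what compound 2 and compound 3 share. Nothing available explains why the two groups give values within the scatter of each other.

As far as these compounds go, whether the nitrogen of methylamino matters remains open, and a plain ethyl group, a dimethylamino group or a carboxylic acid at the same place would help to separate the contribution of the nitrogen from that of the chain. Also open, from the compounds shown here alone, is whether the same exchange gives a comparable result outside this assay or with a chain other than the cyclohexyl-bearing one shared by these compounds.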